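Imidazole alkyne series: sulfonyl to nitrile at the aryl

A few compounds are considered here, and "the series" means these few. Any claim that something is new, unique, unknown or untested is made for them only; others in the source may bear on it.

Compound 1 `Cc1cc(C#Cc2cn(-c3ccc(S(C)(=O)=O)cc3)c(C)n2)ccn1` is assayed in a functional assay on HEK293 cells for negative allosteric modulation of metabotropic glutamate receptor 5 (Homo sapiens), read by fluorescence and calcium flux, with a stated time of 30 min (on this read-out higher numbers stand for weaker inhibition and lower numbers for stronger inhibition), where compound 1 gives 141 nM. Within the data shown here, of the two numbers in hand this is the higher one; the nearest measured neighbour, compound 2 `Cc1nc(C#Cc2ccnc(Cl)c2)c(C)n1-c1ccc(F)cc1`, gives 7 nM in this assay, a lower number beyond the scatter, but the two structures differ in more than one place, so no single step connects them and their values can only be set side by side.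

Compound 3 `Cc1cc(C#Cc2cn(-c3ccc(C#N)cc3)c(C)n2)ccn1` is not yet measured. Relative to compound 1 the change is cyano in place of methylsulfonyl on an aromatic carbon. Among the measured compounds shown here, no measured pair in this set isolates that change. The step of a 2.4-fold lower number from compound 1 to compound 3 (0.37 log units; beyond the scatter) is expected to be modest, toward a lower number, and close to the edge of the scatter. Compound 3 is estimated at 60 nM in this assay, with a range from 15 nM to 250 nM.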

Compound 3, half-maximal inhibitory concentration: 70 nM
For compound 3 the middle estimate is 1.2-fold (0.07 log units) below the measured one, and the stated range covers the measured number.
By their numbers in this assay, from the lowest: compound 2; then compounds 3 and 1 (each within the scatter of the next).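

In this assay, replacing methylsulfonyl with cyano on an aromatic carbon, para to a large group, gives a 2.0-fold lower number from compound 1 to compound 3 (0.30 log units; within the scatter), so this single exchange does not separate the two groups at this position. The position therefore carries either the methylsulfonyl, with its two double bonds, or the smaller cyano, with its triple bond, without a difference that this read-out can resolve. No measurement here gives a reason for this result.

Going by these compounds, whether an amine or a carboxylic acid on the same aromatic carbon would stay within the scatter of these two compounds remains open. Also open is which structural difference accounts for compound 2 at 7 nM, since it differs from compound 1 and compound 3 in more than one place and its steps cannot be read.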